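The source may hold more compounds than are shown below. What is called first, only, known or untested is meant among the compounds shown, and "the series" means these compounds.

Compound 3 `Brc1ccc(Oc2ccc(/C=N/Nc3nc4ccccc4s3)cc2)cc1` is one of three measured members of the series. In a physicochemical assay for lipophilicity, in phosphate buffer, measured as octanol-water partition, with a stated time of 24 h (on this read-out lower numbers stand for lower lipophilicity and higher numbers for higher lipophilicity), compound 3 gives 5.5; compound 1 `O=C(CSc1nc2ccccc2s1)N/N=C/c1ccc(Oc2ccccc2)cc1` gives 5.6 and compound 2 `O=C(CSc1nc2ccccc2s1)N/N=C/c1ccc(Oc2ccc(Cl)cc2)cc1` gives 5.6, and each of these lies within the scatter of the number for compound 3, so the three cannot be told apart on this read-out. Among the compounds with values here, the only step between measured compounds that differ in one place is no change at the digits printed from compound 1 to compound 2 (within the scatter), and it concerns a different exchange of groups.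

Compound 4 `O=[N+]([O-])c1ccc(Oc2ccc(/C=N/Nc3nc4ccccc4s3)cc2)cc1` differs from compound 3 by nitro in place of bromo on an aromatic carbon. Within the data shown here, no measured step replaces bromo by nitro, so the step from compound 1 to compound 2 bears on it only loosely: it shows that one substituent exchange on the outer ring left this assay unmoved, but it does not involve the groups at issue here. Among the measured compounds shown here, with no direct precedent, the expectation for compound 4 is a moderate decrease in this assay, a number 0.50 log units lower from compound 3 to compound 4 (beyond the scatter), beyond the scatter but not large. The estimated value for compound 4 in this assay is 5, with a range from 4.5 to 5.6.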

Compound 4, partition coefficient: 5.1
Estimate against measurement, compound 4: 0.10 log units below; the range from low to high includes it.
By their numbers in this assay, from the lowest: compound 4; then compounds 3, 1 and 2 (each within the scatter of the next).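

Within the data shown here, at this position, on an aromatic carbon para to a large group, the outer ring is not silent: a number 0.40 log units lower from compound 3 to compound 4 (beyond the scatter) in this assay, the first step that clears the scatter, whereas no change at the digits printed from compound 1 to compound 2 (within the scatter), with a different exchange on a different core. The change from 4-bromophenyl to 4-nitrophenyl replaces a single bromine atom with a nitrogen and two oxygen atoms and brings in 2 hydrogen-bond acceptors where bromo has 0, so a modest shift on this read-out can accompany this exchange, though the step alone cannot say which of these differences matters. Nothing available gives a measured reason for the shift.

Open questions remain at this same position: how an unsubstituted phenyl would sit relative to compound 3 and compound 4, and whether an amine, a carboxylic acid or a longer alkoxy chain would fall further along the same direction or back towards compound 3. Also open, going by these compounds, is whether nitro in place of bromo gives a step of similar size on the core of compound 1, where the linker differs.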